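Urea series: isoquinolin-1-yl replacing 3-methylpyridin-2-yl

A few compounds are considered here, and "the series" means these few. Any claim that something is new, unique, unknown or untested is made for them only; others in the source may bear on it.

Of the compounds shown here, three in this set have been measured in a physicochemical assay for lipophilicity, using the shake flask method; on this read-out higher numbers stand for higher lipophilicity and lower numbers for lower lipophilicity. Compound 1 `Cc1cccnc1N(C(=O)N1CCC(c2ccccc2)CC1)[C@@H]1CCCNC1` gives 0.7 in this assay. Compound 2 `O=C(N1CCC(c2cnn3cccnc23)CC1)N(c1ncccc1Cl)[C@@H]1CCCNC1` gives -0.5, and compound 3 `COc1ccc(CCC(=O)N(c2nccc3ccccc23)[C@@H]2CCCNC2)cc1` gives 1. Compound 1 stands second highest of the three; the value of compound 3 lies within the usual scatter of that of compound 1, so no order between the two is drawn, while compound 2 lies beyond the scatter at the lower end. Going by the values given here, no single-point step between measured compounds is available, and compound 3 shares the isoquinolin-1-yl group with compound 4 but differs in the carbonyl part, so it is read only as context.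

Compound 4 `O=C(N1CCC(c2ccccc2)CC1)N(c1nccc2ccccc12)[C@@H]1CCCNC1` is not yet measured. It differs from compound 1 in one place: isoquinolin-1-yl in place of 3-methylpyridin-2-yl on an amide-type nitrogen. The change adds a fused carbon-only aromatic ring and removes the methyl, as counted above.

For compound 4 an increase in this assay is expected, of a size beyond the scatter, amounting to a number 0.70 log units higher from compound 1 to compound 4 (beyond the scatter). The estimated value for compound 4 is 1.4, with a range from 0.9 to 1.9.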

Compound 4, distribution coefficient: 1.4
The estimate for compound 4 equals the measured number at the digits printed; low and high end bracket the measured number.
By their numbers in this assay, from the lowest: compound 2; then compounds 1 and 3 (each within the scatter of the next); then compound 4.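

In this assay, going by these compounds alone, isoquinolin-1-yl in place of 3-methylpyridin-2-yl on an amide-type nitrogen gives a number 0.70 log units higher from compound 1 to compound 4 (beyond the scatter), the first step in this set with only one place changed and thus the first direct reading of this position. Under this change the group grows from 7 to 10 heavy atoms and gains a six-membered aromatic ring of carbon only, while the hydrogen-bond donor and acceptor counts stay the same and neither group carries a net charge. Nothing measured here speaks to the origin of the step.

Still open, as far as these compounds go, is how the step divides between the added fused ring and the removed methyl, as both come in one change, and an unsubstituted pyridin-2-yl group at this place would separate the two. Also open, from the compounds shown here alone, are the size and direction of the step with a polar substituent such as an amine or a carboxylic acid on the isoquinolin-1-yl group, and whether the same step holds with a different carbonyl part on the amide-type nitrogen.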